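Exchanging trifluoromethoxy for ethylsulfanyl on the outer ring

The compounds below may be only part of what the source reports. "The series", "measured", "known", "first", "only" and "open" are said of these compounds alone.

Compound 1, `Oc1ccccc1CNc1ccc(-c2ccccc2)cc1`: 1820 nM
Compound 2, `Oc1ccccc1CNc1ccc(-c2ccc(F)cc2)cc1`: 3860 nM
Compound 3, `Oc1ccccc1CNc1ccc(-c2ccc(OC(F)(F)F)cc2)cc1`: "not active" (no number reported)

These three compounds share one core and differ only in the group carried on the outer ring. In a functional assay on Jurkat cells (Homo sapiens) for activation, with a stated time of 24 h (on this read-out lower numbers stand for an effect already at smaller amounts and higher numbers for an effect only at larger amounts of compound), compound 1 gives 1820 nM, and the step of a 2.1-fold higher number from compound 1 to compound 2 (0.33 log units; beyond the scatter) shows that adding a single fluorine there already weakens the effect by a modest but real amount. Compound 3 stands apart from these numbers: it is reported as "not active" (no number reported), with no single value, so it cannot be placed on the same scale as compound 1 and compound 2.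

Compound 4, `CCSc1ccc(-c2ccc(NCc3ccccc3O)cc2)cc1`, differs from compound 3 by ethylsulfanyl in place of trifluoromethoxy on an aromatic carbon. Among the measured compounds shown here, the only measured step, a 2.1-fold higher number from compound 1 to compound 2 (0.33 log units; beyond the scatter), concerns a different exchange at this position and therefore bears only loosely on the present change; it shows that this position tolerates change poorly, nothing more. With compound 3 giving no number, the direction of the step cannot be read from the data. Compound 4 is expected to give about 6000 nM in this assay. Its estimated range runs from 1500 nM to 30000 nM.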

Compound 4, half-maximal effective concentration: 1980 nM
Compound 4: the middle estimate sits 3.0-fold (0.48 log units) above what was measured; the measured number falls inside the stated range.
By their numbers in this assay, from the lowest: compounds 1, 4 and 2 (each within the scatter of the next, the first and the last beyond it).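

Compound 4 shows that a group larger than fluoro can sit on this outer ring, para to a large group, and still give a measured effect, whereas compound 3, with trifluoromethoxy at the same place, was reported as "not active". Among the compounds shown here, that exchange has no step that can be read, since compound 3 has no number. In this assay, ethylsulfanyl cannot be told apart from the other two groups: both a 1.9-fold lower number from compound 2 to compound 4 (0.29 log units; within the scatter) and a 1.1-fold higher number from compound 1 to compound 4 (0.04 log units; within the scatter) lie within the scatter.

Nothing here measures why ethylsulfanyl and trifluoromethoxy give such different reports. The compounds shown leave open whether ethylsulfanyl is a special case, and how an amine, a carboxylic acid or a longer sulfur-linked chain such as butylsulfanyl would read at this place.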